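The source may hold more compounds than are shown below. What is called first, only, known or untested is meant among the compounds shown, and "the series" means these compounds.

Measured so far in an ADME assay on BCBL1 cells (Homo sapiens) for cytotoxicity, with a stated time of 7 days; a lower number here means that less compound is tolerated, a higher number that more compound is tolerated:
compound 1, `CC(C)Nc1nc(N)nc2c1ncn2/C=C1/CC1(CO)CO`: > 20000 nM
compound 2, `CCCNc1nc(N)nc2c1ncn2/C=C1/CC1(CO)CO`: > 20000 nM

Compound 1 reaches only a limit of this assay, > 20000 nM. Compound 2 likewise stops at a limit, > 20000 nM. For the measured compounds named here, the one recorded step, a step that the two limits leave unreadable from compound 1 to compound 2, cannot be sized because both values sit at the limit of > 20000 nM in this assay, at which 2 of the 2 values shown sit. Compound 3, `Nc1nc(SCc2ccccc2)c2ncn(/C=C3/CC3(CO)CO)c2n1`, is not yet measured; relative to compound 1 it carries benzylsulfanyl in place of isopropylamino on an aromatic carbon. Going by the values given here, no measured step covers this change, so no direction can be read from the series. Compound 3 is therefore expected to remain near the limit, with an expected step of a number no higher from compound 1 to compound 3 (the limit leaves the size open). Compound 3 is estimated at 20000 nM, within 7000 nM to 60000 nM.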

Compound 3, half-maximal cytotoxic concentration: > 20000 nM
Compound 3 gave a limit, no number (the forecaster's own chance of this, stated with the estimate: 60%); the middle value lies on the limit itself.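

Compound 1, compound 2 and compound 3 give no readable step in this assay, each value being a limit and not a number: the limit of > 20000 nM in this assay, at which 3 of the 3 values shown sit. The compounds shown leave open at what concentration the shared core becomes cytotoxic, and whether benzylsulfanyl, isopropylamino and propylamino differ at all.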